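Shifting the Nitrile and Adding Fluorine on One Aryl Ring

The compounds below may be only part of what the source reports. "The series", "measured", "known", "first", "only" and "open" are said of these compounds alone.

Three measured compounds share one core and differ only in a single aryl group. Compound 1 `CC/C(=C(/c1ccc(/C=C/C(=O)O)cc1)c1cc2ccccc2[nH]1)c1cccc(C)c1` carries 3-methylphenyl; in a functional assay on MCF7 cells (Homo sapiens) for inhibition (on this read-out higher numbers stand for weaker inhibition and lower numbers for stronger inhibition), compound 1 gives 140 nM. Compound 2 `CC/C(=C(/c1ccc(/C=C/C(=O)O)cc1)c1cc2ccccc2[nH]1)c1ccc(Cl)cc1` carries 4-chlorophenyl and in this assay compound 2 gives 343 nM. Compound 3 `CC/C(=C(/c1ccc(/C=C/C(=O)O)cc1)c1cc2ccccc2[nH]1)c1ccc(C#N)cc1` carries 4-cyanophenyl and in this assay compound 3 gives 278 nM. Compound 3 sits close to both others: a 1.2-fold lower number from compound 2 to compound 3 (0.09 log units; within the scatter), and a 2.0-fold higher number from compound 1 to compound 3 (0.30 log units; within the scatter). Only a 2.5-fold higher number from compound 1 to compound 2 (0.39 log units; beyond the scatter) passes the scatter. Compound 4 `CC/C(=C(/c1ccc(/C=C/C(=O)O)cc1)c1cc2ccccc2[nH]1)c1cccc(F)c1C#N` differs from compound 3 by 2-cyano-3-fluorophenyl in place of 4-cyanophenyl on a double-bonded chain carbon bound to a double-bonded chain carbon and a saturated chain carbon. The measured aryl swaps moved the numbers little or modestly, so no step beyond the scatter is expected, and the expected change is a 1.1-fold higher number from compound 3 to compound 4 (0.03 log units; within the scatter). Compound 4 is expected to give 300 nM, with a range of 120 nM to 750 nM.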

Compound 4, half-maximal inhibitory concentration: 40 nM
Compound 4: middle estimate off by 7.5-fold (0.88 log units), on the high side, and the stated range ends above it.
By their numbers in this assay, from the lowest: compound 4; then compounds 1, 3 and 2 (each within the scatter of the next, the first and the last beyond it).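

At this position, 2-cyano-3-fluorophenyl gives a 7.0-fold lower number from compound 3 to compound 4 (0.84 log units; beyond the scatter) in this assay, a far larger step than the earlier aryl swaps produced. It also outperforms the other aryl groups, with an 8.6-fold lower number from compound 2 to compound 4 (0.93 log units; beyond the scatter) and a 3.5-fold lower number from compound 1 to compound 4 (0.54 log units; beyond the scatter), making compound 4 the strongest inhibitor of the four. No evidence here explains this gain.

On these data alone, the change moves the nitrile and adds fluorine at once, so the share of each stays open. Also open, as far as these compounds go, is how an amine or a carboxylic acid on this ring would fare.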